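Methyl in Place of Fluoro on Compound 1

The source may report more compounds than this note shows. Statements on the series, on what has been measured and on what is new or still open speak of the compounds shown alone.

Among the measured compounds shown here, compound 1 `O=C1CC(c2nc(-c3ccccc3)no2)CN1c1ccc(F)cc1` is one of two compounds measured so far. In an in vitro functional assay on HEK293-A cells for positive allosteric modulation of metabotropic glutamate receptor 5 (Homo sapiens), read by FLIPR and calcium flux (on this read-out lower numbers stand for an effect already at smaller amounts and higher numbers for an effect only at larger amounts of compound), compound 1 gives 58 nM, the lowest of the two numbers, with compound 2 `O=C1CC(c2nc(-c3cccc(F)c3)no2)CN1c1ccc(F)cc1` the nearest to it; in this assay compound 2 gives 88 nM. The step of a 1.5-fold higher number from compound 1 to compound 2 (0.18 log units; within the scatter) came from a fluoro in place of hydrogen on an aromatic carbon. Compound 3 `Cc1ccc(N2CC(c3nc(-c4ccccc4)no3)CC2=O)cc1` has not yet been measured. It differs from compound 1 by methyl in place of fluoro on an aromatic carbon. For the measured compounds named here, no measured step bears on this change: the single step seen so far put a fluoro in at a different aromatic carbon, and it stayed within the scatter. With nothing pointing in either direction, compound 3 is expected to show a step of a 1.1-fold higher number from compound 1 to compound 3 (0.05 log units; within the scatter) that does not go beyond the scatter. The estimate for compound 3 in this assay is accordingly 65 nM, within a range from 25 nM to 180 nM.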

Compound 3, half-maximal effective concentration: 384 nM
For compound 3 the middle estimate is 5.9-fold (0.77 log units) below the measured one; measured number above the stated range.
By their numbers in this assay, from the lowest: compounds 1 and 2 (each within the scatter of the next); then compound 3.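

Exchanging 4-fluorophenyl for 4-methylphenyl gives a 6.6-fold higher number from compound 1 to compound 3 (0.82 log units; beyond the scatter) in this assay, so this carbon, para to a large group, responds clearly to a change of a single heavy atom, with no change in ring, charge or the count of hydrogen-bond donors and acceptors. Among the compounds shown here, this is the first step to go beyond the scatter, whereas the fluoro placed at a different aromatic carbon, in a 1.5-fold higher number from compound 1 to compound 2 (0.18 log units; within the scatter), stayed within it. No measurement at hand speaks to the cause of the new step.

The compounds shown leave open how hydrogen, chloro, methoxy or an amine at this carbon would compare with fluoro and methyl. They also leave open whether the same exchange would give a step of like size on compound 2.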